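Quinolinyl ether series: cytotoxicity notes ahead of compound 3

The source may report more compounds than this note shows. Statements on the series, on what has been measured and on what is new or still open speak of the compounds shown alone.

Measured so far:
compound 1: `C=C1CC[C@@H]2[C@](C)(CO)[C@H](O)CC[C@@]2(C)[C@@H]1C/C=C1/C(=O)OC[C@@H]1Oc1cccc2ccc(C)nc12` — in an ADME assay on SNB-19 cells (Homo sapiens) for cytotoxicity, read by MTT assay, with a stated time of 24 h (on this read-out lower numbers stand for higher toxicity in this test and higher numbers for lower toxicity in this test), compound 1 gives > 100000 nM, which is the assay limit and not a number.
compound 2: `C=C1CC[C@@H]2[C@](C)(CO)[C@H](O)CC[C@@]2(C)[C@@H]1C/C=C1/C(=O)OC[C@@H]1Oc1c(Cl)cc(Cl)c2cccnc12` — in this assay compound 2 gives > 100000 nM, again only the assay limit.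

Both measured entries carry the aryl ether on an oxygen on a saturated carbon of the shared core. The step that the two limits leave unreadable from compound 1 to compound 2 cannot be sized; both values sit at the limit of > 100000 nM in this assay, at which 2 of the 2 values shown sit, so compound 2 stands at the limit together with compound 1, with no readable difference between them.

Compound 3 is `C=C1CC[C@@H]2[C@](C)(CO)[C@H](O)CC[C@@]2(C)[C@@H]1C/C=C1/C(=O)OC[C@@H]1Oc1ccnc2ccccc12`. Relative to compound 2 the change is quinolin-4-yl in place of 5,7-dichloroquinolin-8-yl on an oxygen on a saturated carbon. Among the measured compounds shown here, the only measured step, the change from compound 1 to compound 2, bears on it in that it also exchanges one quinolinyl group for another on the same oxygen, yet its size is not readable. For the measured compounds named here, no measured step gives a magnitude, so the expectation for compound 3 rests on both measured compounds sitting at the limit, and the estimated step of a number no higher from compound 2 to compound 3 (the limit leaves the size open) is none beyond the scatter. Compound 3 is therefore expected at about 100000 nM, within 30000 nM to 300000 nM, and most likely reported only as a limit.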

Compound 3, half-maximal cytotoxic concentration: 61200 nM
Beside the measured number, compound 3's estimate is 1.6-fold (0.21 log units) above it, and the stated range covers the measured number.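

In this assay, among the compounds shown here, compound 3 gives 61200 nM, the first value that is a number, so an aryl ether on this oxygen on a saturated carbon can give a readable value. As far as these compounds go, the comparisons now read as an at least 1.6-fold lower number from compound 2 to compound 3 (0.21 log units; that floor lies within the scatter) and as an at least 1.6-fold lower number from compound 1 to compound 3 (0.21 log units; that floor lies within the scatter); each is only a floor, so the true size of either step remains unknown, and neither floor alone establishes a difference beyond the scatter. The assay limit still holds for most of the compounds shown: the limit of > 100000 nM in this assay, at which 2 of the 3 values shown sit.

Both steps alter the attachment of the quinoline and remove substituents at once, so the compounds shown do not separate the effect of the quinolin-4-yl attachment from that of losing the chlorines or the methyl group. Unsubstituted quinolin-8-yl would address that question, and a quinolin-4-yl group bearing chlorine, methyl or an amine would show whether the value in this assay moves beyond the scatter when this group is substituted.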